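Changing the acyl group on a naphthalene amide

A few compounds are considered here, and "the series" means these few. Any claim that something is new, unique, unknown or untested is made for them only; others in the source may bear on it.

Two compounds share a core built from a naphthalene carrying an amide nitrogen and a hexafluoro carbinol. Compound 1 `CCC(=O)Nc1c(C(O)(C(F)(F)F)C(F)(F)F)ccc2ccccc12` carries a propanoyl group; in a functional assay (Sus scrofa) with sulfonylurea receptors; K-ATP channels (Homo sapiens) as the target (a higher number here means that more compound is needed for the effect, a lower number that less compound is needed), compound 1 gives 8.91 nM. Compound 2 `O=C(Nc1c(C(O)(C(F)(F)F)C(F)(F)F)ccc2ccccc12)C1CC1` carries a cyclopropylcarbonyl group; in this assay compound 2 gives 126 nM. Within the data shown here, the one measured step, a 14-fold higher number from compound 1 to compound 2 (1.15 log units; beyond the scatter), is large. Compound 2 therefore stands at the higher of the two numbers, with compound 1 far below it.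

Compound 3 `O=C(Nc1c(C(O)(C(F)(F)F)C(F)(F)F)ccc2ccccc12)c1cccc(Cl)c1` continues along the same place on the carbonyl carbon: 3-chlorophenyl in place of cyclopropyl on a carbonyl carbon. Among the measured compounds shown here, the only step that bears on this change is the earlier one from compound 1 to compound 2, and it showed that replacing a small group on this carbonyl carbon with a ring pushed the number up strongly. A 3-chlorophenyl ring is a much larger group again, so a further rise beyond the scatter is expected, though its size is uncertain with one step to go on. For compound 3 the expected step is a 2.4-fold higher number from compound 2 to compound 3 (0.38 log units; beyond the scatter), and the estimated value is 300 nM, with a range from 60 nM to 1500 nM.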

Compound 3, half-maximal effective concentration: 851 nM
Compound 3: middle estimate off by 2.8-fold (0.45 log units), on the low side; the range from low to high includes it.
By their numbers in this assay, from the lowest: compound 1; then compound 2; then compound 3.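

The rise seen with cyclopropyl continues with a larger, aromatic ring on the same carbonyl carbon: in this assay there is a 6.8-fold higher number from compound 2 to compound 3 (0.83 log units; beyond the scatter) for the swap from a three-membered non-aromatic ring to 3-chlorophenyl. Among these compounds, this position has now given two steps in the same direction, and across the set there is a 96-fold higher number from compound 1 to compound 3 (1.98 log units; beyond the scatter) when ethyl gives way to 3-chlorophenyl, so the ethyl of compound 1 has the lowest number of the three and no compound here goes against that order. Nothing available explains why the number climbs along this series.

The compounds shown leave open whether the latest rise belongs to the aromatic ring itself or to its chlorine, a question that an unsubstituted phenyl on the same carbonyl carbon could help to separate. They also leave open how far the trend holds for other groups at this place, such as a methyl, a longer chain like butyl, or a ring carrying an amine.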